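A few compounds are considered here, and "the series" means these few. Any claim that something is new, unique, unknown or untested is made for them only; others in the source may bear on it.

Among the measured compounds shown here, compound 2 `COc1ccc(N/C(CCNC2=CC(=O)c3ccccc3C2=O)=N\S(=O)(=O)c2ccc(C)cc2)cc1OC` is one of two compounds measured in a functional assay on HeLa cells (Homo sapiens) for cytotoxicity, read by MTT assay, with a stated time of 48 h; a lower number here means a stronger inhibitor, a higher number a weaker inhibitor. Compound 2 gives 14500 nM, the higher of the two numbers, and its nearest neighbour is compound 1 `Cc1ccc(S(=O)(=O)/N=C(/CCNC2=CC(=O)c3ccccc3C2=O)Nc2cccc(C)c2)cc1`, which in this assay gives 9060 nM. For the measured compounds named here, the single measured step, a 1.6-fold higher number from compound 1 to compound 2 (0.20 log units; within the scatter), exchanges one aryl group for another on an amine nitrogen and stays within the scatter. Compound 3 `Cc1ccc(S(=O)(=O)/N=C(/CCNC2=CC(=O)c3ccccc3C2=O)Nc2ccc(F)c(F)c2)cc1` differs from compound 2 at the same position: 3,4-difluorophenyl in place of 3,4-dimethoxyphenyl on an amine nitrogen. Going by the values given here, the only step that bears on this change is a 1.6-fold higher number from compound 1 to compound 2 (0.20 log units; within the scatter), and it shows that exchanging the aryl group on that nitrogen did not shift the number beyond the scatter. For compound 3 no step beyond the scatter is therefore expected in this assay, in either direction, and the step that this estimate means, a 1.3-fold lower number from compound 2 to compound 3 (0.12 log units; within the scatter), is expected to remain within the scatter. Compound 3 is thus estimated to give 11000 nM in this assay, with a range from 4000 nM to 30000 nM.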

Compound 3, half-maximal inhibitory concentration: 8790 nM
Compound 3: middle estimate off by 1.3-fold (0.10 log units), on the high side; the measured number falls inside the stated range.
By their numbers in this assay, from the lowest: compounds 3, 1 and 2 (each within the scatter of the next).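

With compound 3 the amine nitrogen carries a third aryl group, and in this assay the exchange of 3,4-dimethoxyphenyl for 3,4-difluorophenyl amounts to a 1.6-fold lower number from compound 2 to compound 3 (0.22 log units; within the scatter), while the exchange of 3-methylphenyl for 3,4-difluorophenyl amounts to a 1.0-fold lower number from compound 1 to compound 3 (0.01 log units; within the scatter). The earlier pair offered a single exchange at this position, whereas the three compounds now give three exchanges, none of which leaves the scatter, and this holds even though the 3,4-dimethoxyphenyl group counts 2 hydrogen-bond acceptors and the 3,4-difluorophenyl group counts 0. Nothing measured beyond these numbers offers an explanation for this result.

On these data alone, all three compounds carry a substituted phenyl group on this nitrogen, so it remains open whether a phenyl group bearing a carboxylic acid or an amine, a benzyl group, or a cyclohexyl group would give a step beyond the scatter. The rest of the structure is the same in all three compounds, so these compounds also cannot show what a longer chain in the shared core, or a different group on the sulfonyl, would do to the number.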